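Diethoxy substitution on the benzoate ester of a bicyclic diester

The compounds below may be only part of what the source reports. "The series", "measured", "known", "first", "only" and "open" are said of these compounds alone.

Compound 3 `CC(=O)Oc1ccccc1C(=O)O[C@H]1CO[C@H]2[C@@H]1OC[C@H]2OC(=O)c1ccccc1` is one of three esters built on a shared core and measured in an ADME assay on a cell-free system (plasma, Homo sapiens) for metabolic stability, with Plasma (Rattus norvegicus) as the target, read by HPLC, at pH 7.4; on this read-out lower numbers stand for a shorter-lived compound and higher numbers for a longer-lived compound; there compound 3 gives 0.0107 h. On these numbers compound 3 stands second highest of three, yet its gaps to compound 2 `CCC(=O)O[C@@H]1CO[C@H]2[C@@H]1OC[C@@H]2OC(=O)c1ccccc1OC(C)=O` with 0.011 h and to compound 1 `CC(=O)Oc1ccccc1C(=O)O[C@H]1CO[C@H]2[C@@H]1OC[C@H]2OC(C)=O` with 0.0095 h are both within the scatter. Compound 4 `CCOc1cc(OCC)cc(C(=O)O[C@@H]2CO[C@H]3[C@@H]2OC[C@@H]3OC(=O)c2ccccc2OC(C)=O)c1` differs from compound 3 by 3,5-diethoxyphenyl in place of phenyl on a carbonyl carbon. The steps that touch the same carbonyl carbon, a 1.1-fold higher number from compound 1 to compound 3 (0.05 log units; within the scatter) and a 1.0-fold lower number from compound 2 to compound 3 (0.01 log units; within the scatter), were both within the scatter, so exchanging the group on that carbon has so far left this read-out unmoved. Among the measured compounds shown here, no measured step changes substituents on the aromatic ring itself, so the account is thin. Compound 4 is therefore expected to stay within the scatter of compound 3, with a 1.0-fold higher number from compound 3 to compound 4 (0.01 log units; within the scatter), estimated at 0.011 h between 0.005 h and 0.025 h.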

Compound 4, half-life: 0.0283 h
Compound 4: middle estimate off by 2.6-fold (0.41 log units), on the low side; the measured number lies above the stated range.
By their numbers in this assay, from the lowest: compounds 1, 3 and 2 (each within the scatter of the next); then compound 4.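

In this assay, this carbonyl carbon proves able to move the read-out: 3,5-diethoxyphenyl gives a modest rise over phenyl (a 2.6-fold higher number from compound 3 to compound 4 (0.42 log units; beyond the scatter)), over ethyl (a 2.6-fold higher number from compound 2 to compound 4 (0.41 log units; beyond the scatter)) and over methyl (a 3.0-fold higher number from compound 1 to compound 4 (0.47 log units; beyond the scatter)). The earlier exchanges among methyl, ethyl and phenyl on this carbon had all stayed within the scatter, so the position is not indifferent to every group. Nothing measured here accounts for the rise.

On these data alone, whether both ethoxy groups are needed remains open. So does whether a single ethoxy group, methoxy groups or an amine on the same phenyl ring would give a similar step.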